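From Carboxylic Acid to tert-Butyl Amide in HeLa Cytotoxicity

A few compounds are considered here, and "the series" means these few. Any claim that something is new, unique, unknown or untested is made for them only; others in the source may bear on it.

Measured compounds:
compound 1, `C=CC1=C(C(=O)O)C(c2ccc(F)cc2)OC1`: 67400 nM
compound 2, `C=CC1=C(C(=O)O)C(c2ccc(OC)cc2)OC1`: 44300 nM
compound 3, `C=CC1=C(C(=O)NC(C)(C)C)C(c2ccc(Cl)c(Cl)c2)OC1`: > 100000 nM (a limit)

In a functional assay on HeLa cells (Homo sapiens) for cytotoxicity, read by MTT assay, with a stated time of 24 h (on this read-out lower numbers stand for stronger inhibition and higher numbers for weaker inhibition), compound 1 gives 67400 nM. Compound 2 stands apart from it by a 1.5-fold lower number from compound 1 to compound 2 (0.18 log units; within the scatter), a step the data place within the scatter, so the two are not ordered. Compound 3 reports only a limit in this assay, > 100000 nM.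

Compound 4, `C=CC1=C(C(=O)NC(C)(C)C)C(c2ccc(F)cc2)OC1`, differs from compound 1 by (tert-butyl)amino in place of hydroxy on a carbonyl carbon. Within the data shown here, no measured step follows this change directly; the only measured step concerns the aromatic substituent. Compound 3 carries the same (tert-butyl)carbamoyl and sits at the limit of > 100000 nM in this assay, at which 1 of the 3 values shown sits, which points toward a higher number. Compound 4 is therefore expected at 110000 nM, within 50000 nM to 300000 nM. The expected step is a 1.6-fold higher number from compound 1 to compound 4 (0.21 log units; within the scatter), with a fair chance that only a limit is reported.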

Compound 4, half-maximal inhibitory concentration: > 100000 nM
Compound 4 gave a limit, no number; the forecaster's own chance of this, stated with the estimate: 55%; the middle value lies beyond the limit too.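

Among these compounds, the earlier compounds varied only the aromatic substituent, whereas compound 4 gives the first reading in this assay of a change on the carbonyl carbon. As far as these compounds go, that step is an at least 1.4-fold higher number from compound 1 to compound 4 (0.17 log units; that floor lies within the scatter); compound 4 reports a limit, so only this floor is known and the true size of the step stays unknown. Both compounds shown with (tert-butyl)carbamoyl now sit at that limit: the limit of > 100000 nM in this assay, at which 2 of the 4 values shown sit.

From the compounds shown here alone, whether a plain amino or methylamino group in place of hydroxy would give a measurable number remains open. So does whether a methyl ester at this carbonyl carbon would.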